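The source may report more compounds than this note shows. Statements on the series, on what has been measured and on what is new or still open speak of the compounds shown alone.

Working notes on the series. Among the compounds with values here, compound 2 `CCCCCOc1nc(N)c2nc(O)n(Cc3ccccc3)c2n1` gives the lowest of the two numbers so far in a functional assay (spleen, spleen) for activation, with Mus musculus as the target (on this read-out lower numbers stand for an effect already at smaller amounts and higher numbers for an effect only at larger amounts of compound), with compound 2 at 0.01 uM; the nearest measured point is compound 1 `CCCCCNc1nc(N)c2nc(O)n(Cc3ccccc3)c2n1`, which in this assay gives 0.1 uM. Within the data shown here, the single step within the pair, a 10-fold lower number from compound 1 to compound 2 (1.00 log units; beyond the scatter), is the only one that bears on the next change. Compound 3 `CCNc1nc(N)c2nc(O)n(Cc3ccccc3)c2n1` differs from compound 2 by ethylamino in place of pentyloxy on an aromatic carbon. Among the measured compounds shown here, the move from an alkoxy back to an alkylamino substituent runs counter to that measured step, so a higher number is expected; the shortening from a pentyl to an ethyl chain has no measured counterpart here and adds uncertainty. For compound 3 the expected step is a 30-fold higher number from compound 2 to compound 3 (1.48 log units; beyond the scatter), an increase beyond the scatter. Compound 3 is therefore estimated at 0.3 uM, with a range from 0.05 uM to 3 uM.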

Compound 3, minimum effective concentration: 1 uM
For compound 3 the middle estimate is 3.3-fold (0.52 log units) below the measured one; measured number inside the range.
By their numbers in this assay, from the lowest: compound 2; then compound 1; then compound 3.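

With the amino link held constant, the step from pentylamino to ethylamino isolates chain length at this position, something the earlier pair could not show: in this assay there is a 10-fold higher number from compound 1 to compound 3 (1.00 log units; beyond the scatter). The full replacement of pentyloxy by ethylamino gives a 100-fold higher number from compound 2 to compound 3 (2.00 log units; beyond the scatter), so this larger step combines the change of link with the shorter chain, and the chain alone moves the number beyond the scatter. Nothing available explains either step.

The compounds shown leave open whether an oxygen link would give the same gain on a short chain as on the pentyl chain, which an ethoxy group at this position would test. They also leave open how the number responds to a chain longer than pentyl, such as heptyloxy or heptylamino.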